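Changing the benzyl group on a short-lived compound

The source may hold more compounds than are shown below. What is called first, only, known or untested is meant among the compounds shown, and "the series" means these compounds.

In an ADME assay on microsomes from liver (Rattus norvegicus) for metabolic stability (a higher number here means that the compound lasts longer, a lower number that the compound disappears faster), compound 3 (`CCS(=O)(=O)c1ccc(CNC(=O)c2ccc3c(c2)cc(Cc2ccccc2OC)n3C(C)C)cc1`) gives 0.2 h. Going by the values given here, compound 2 (`CCS(=O)(=O)c1ccc(CNC(=O)c2ccc3c(c2)cc(Cc2ccccc2Br)n3C(C)C)cc1`) gives 0.2 h, so these two share the lowest number so far. Compound 1 (`CCS(=O)(=O)c1ccc(CNC(=O)c2ccc3c(c2)cc(Cc2ccc(Cl)cc2C(F)(F)F)n3C2CC2)cc1`) stands well apart at 1.7 h.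

Compound 4 (`CCS(=O)(=O)c1ccc(CNC(=O)c2ccc3c(c2)cc(Cc2ccc(Cl)cc2C(F)(F)F)n3C(C)C)cc1`) departs from compound 3 in one place: 4-chloro-2-(trifluoromethyl)phenyl in place of 2-methoxyphenyl on a saturated chain carbon bound to an aromatic carbon. Cut one bond further out, this reads 2-methoxybenzyl to 4-chloro-2-(trifluoromethyl)benzyl.

Among the compounds with values here, only one measured step touches this part of the molecule. It is no change at the digits printed from compound 2 to compound 3 (within the scatter), where methoxy takes the place of bromo, and it says little about the larger group entering here. The better clue is compound 1 at 1.7 h, which already carries 4-chloro-2-(trifluoromethyl)phenyl. However, compound 1 also differs from compound 4 elsewhere on the core, and no measured step isolates the group itself. Only part of that gap is therefore expected to carry over. The expected change is a 3.5-fold higher number from compound 3 to compound 4 (0.54 log units; beyond the scatter) in this assay, towards a longer half-life. For compound 4, the estimated half-life is 0.7 h, within an expected range of 0.3 h to 1.6 h.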

Compound 4, half-life: 1.93 h
Estimate against measurement, compound 4: 2.8-fold (0.44 log units) below; measured number outside the range, above it.
By their numbers in this assay, from the lowest: compounds 2 and 3 (each within the scatter of the next); then compounds 1 and 4 (each within the scatter of the next).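

Swapping only the group on the saturated chain carbon gives a 9.7-fold higher number from compound 3 to compound 4 (0.98 log units; beyond the scatter) in this assay and, starting from the 2-bromophenyl compound, a 9.7-fold higher number from compound 2 to compound 4 (0.98 log units; beyond the scatter) as well. So this position can move the half-life well beyond the scatter, and 4-chloro-2-(trifluoromethyl)phenyl brings that gain with the rest of the molecule unchanged. The other single change, on the aromatic nitrogen, gives a 1.1-fold higher number from compound 1 to compound 4 (0.06 log units; within the scatter) and so shows that isopropyl and cyclopropyl cannot be told apart here when this group is present; nothing measured here bears on why the half-life changes.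

The entering group carries chloro and trifluoromethyl together, so a phenyl ring with only one of them would be needed to show which matters. As far as these compounds go, whether a longer chain or an amine on the aromatic nitrogen would hold this half-life also remains open.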